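The source may hold more compounds than are shown below. What is called first, only, known or untested is meant among the compounds shown, and "the series" means these compounds.

Of the compounds shown here, three that share one core have been tested in a functional assay on WI-38 VA13 cells (Homo sapiens) for cytotoxicity; on this read-out higher numbers stand for an effect only at larger amounts of compound and lower numbers for an effect already at smaller amounts. In this assay compound 1 `O=C(Nc1ccc2nc(NC(=O)C3CCCCC3)sc2c1)c1ccccc1Oc1ccccc1` gives 0.1 ug/mL. Compound 2 `CCCC(C)C(=O)Nc1ccc2nc(NC(=O)C3CCCCC3)sc2c1` gives 0.14 ug/mL. Compound 3 `CC(=O)Nc1nc2ccc(NC(=O)c3c(Cl)cccc3Cl)cc2s1` gives 0.6 ug/mL, the highest of the three numbers; its gap to compound 2 and its larger gap to compound 1 both lie beyond the usual scatter, so compound 3 acts only at larger amounts of compound than either of the other two.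

Compound 4 `CC(C)(C)OC(=O)Nc1nc2ccc(NC(=O)c3c(Cl)cccc3Cl)cc2s1` has not yet been measured. It differs from compound 3 in a single place: tert-butoxy in place of methyl on a carbonyl carbon. For the measured compounds named here, no pair of measured compounds differs in exactly this way, so the numbers so far give no direct guide to the direction of this change. The step of a 1.2-fold lower number from compound 3 to compound 4 (0.08 log units; within the scatter) is therefore expected to stay within the scatter, with no clear direction. For compound 4 the estimate is 0.5 ug/mL, with a range from 0.15 ug/mL to 1.8 ug/mL.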

Compound 4, half-maximal effective concentration: 0.027 ug/mL
For compound 4 the middle estimate is 19-fold (1.27 log units) above the measured one; measured number below the stated range.
By their numbers in this assay, from the lowest: compound 4; then compounds 1 and 2 (each within the scatter of the next); then compound 3.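

Replacing methyl with tert-butoxy on this carbonyl carbon, which turns the acetamido group into a (tert-butoxycarbonyl)amino group, produces a large shift in this assay (a 22-fold lower number from compound 3 to compound 4 (1.35 log units; beyond the scatter)). This place on the core, a carbonyl carbon whose other neighbour is an amide-type nitrogen, is therefore far from silent: with tert-butoxy there, cytotoxicity appears at much smaller amounts of compound than with methyl. Nothing measured here explains why the number falls.

Still open, on these data alone, is which part of the tert-butoxy group matters: methoxy would keep the oxygen without the branched carbons, while tert-butyl would keep the branched carbons without the oxygen. This single pair also leaves open whether the same change gives a step of this size when other groups sit elsewhere on the shared core.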